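Ring Size at the Carboxy-Bearing Amide Nitrogen

A few compounds are considered here, and "the series" means these few. Any claim that something is new, unique, unknown or untested is made for them only; others in the source may bear on it.

Compound 3 `O=C(NC1(C(=O)O)CCCC1)c1cc(F)cc2cc(-c3ccc(Cl)cc3)oc12` carries a 1-carboxycyclopentyl group on an amide-type nitrogen. In an assay on isolated protein for inhibition of endoplasmic reticulum aminopeptidase 2 (Homo sapiens) (a lower number here means a stronger inhibitor, a higher number a weaker inhibitor), compound 3 gives only a limit of the assay, > 30000 nM. Its neighbour compound 2 `O=C(NC1(C(=O)O)CC1)c1cc(F)cc2cc(-c3ccc(Cl)cc3)oc12`, which carries the smaller 1-carboxycyclopropyl group on the same nitrogen, also sits at a limit: in this assay compound 2 gives > 30000 nM. For compound 1 `C[C@H](NC(=O)c1cc(F)cc2cc(-c3ccc(Cl)cc3)oc12)C(=O)O` the outcome in this assay is "not determined" (no result reported). So compound 3 stands at the limit, as does compound 2, and nothing separates the two. Compound 4 `O=C(NC1(C(=O)O)CCCCC1)c1cc(F)cc2cc(-c3ccc(Cl)cc3)oc12` is the next ring size up: 1-carboxycyclohexyl in place of 1-carboxycyclopentyl on an amide-type nitrogen. Going by the values given here, the only measured step of this kind is a step that the two limits leave unreadable from compound 2 to compound 3, and because the limit of > 30000 nM in this assay, at which 2 of the 3 values shown sit, its size cannot be read; no direction can be taken from it. Nothing beyond the scatter is therefore expected from enlarging the ring, and the step that the limit leaves unreadable from compound 3 to compound 4 is expected to leave compound 4 at the limit as well. Compound 4 is thus estimated at 40000 nM, within 15000 nM to 120000 nM.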

Compound 4, half-maximal inhibitory concentration: > 30000 nM
Compound 4: only a limit was reported (the forecaster's own chance of this, stated with the estimate: 85%); the middle value does not contradict the limit.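

Compound 4 also gives only a limit, so neither its step from compound 3 nor its step from compound 2 can be read: the limit of > 30000 nM in this assay, at which 3 of the 4 values shown sit. The compounds shown leave open how strongly any of these ring sizes on the amide-type nitrogen inhibits in this assay.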